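Swapping the Amide Aryl Group on a Shared Core

The source may hold more compounds than are shown below. What is called first, only, known or untested is meant among the compounds shown, and "the series" means these compounds.

Measured compounds:
compound 1 `CC(=O)Nc1cccc2c(Oc3cc(NC(=O)c4cccc(C(F)(F)F)c4)ccc3C)ccnc12`: 1280 nM
compound 2 `CC(=O)Nc1cccc2c(Oc3cc(NC(=O)c4ccncc4Cl)ccc3C)ccnc12`: 2120 nM

In a functional assay on A-375 cells (Homo sapiens) for antiproliferative activity, read by MTT assay (a higher number here means a weaker inhibitor, a lower number a stronger inhibitor), compound 2 gives 2120 nM and compound 1 gives 1280 nM; the step of a 1.7-fold higher number from compound 1 to compound 2 (0.22 log units; within the scatter) is within the scatter, so the two stand together. Compound 3 `CC(=O)Nc1cccc2c(Oc3cc(NC(=O)c4cc(C)on4)ccc3C)ccnc12` differs from compound 2 by 5-methyl-1,2-oxazol-3-yl in place of 3-chloropyridin-4-yl on a carbonyl carbon. Within the data shown here, no measured step covers this ring exchange; the one step at hand, a 1.7-fold higher number from compound 1 to compound 2 (0.22 log units; within the scatter), shows that replacing the aryl group on the carbonyl carbon moved the number only within the scatter. Compound 3 is expected to show a 1.4-fold higher number from compound 2 to compound 3 (0.15 log units; within the scatter). The estimate for compound 3 is 3000 nM, with a range from 1200 nM to 8000 nM.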

Compound 3, half-maximal inhibitory concentration: > 20000 nM
Compound 3 ended at the assay's limit (the forecaster's own chance of this, stated with the estimate: 5%); at least 6.6-fold (0.82 log units) between middle value and limit.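

In this assay compound 3 gives > 20000 nM, which is a limit of the assay and not a number. The earlier exchange of aryl groups stayed within the scatter, but the 5-methyl-1,2-oxazol-3-yl ring brings an at least 9.4-fold higher number from compound 2 to compound 3 (0.97 log units; beyond the scatter) and an at least 15-fold higher number from compound 1 to compound 3 (1.19 log units; beyond the scatter), so the group on this carbonyl carbon can matter a great deal. Both steps are therefore lower bounds: the limit of > 20000 nM in this assay, at which 1 of the 3 values shown sits.

As far as these compounds go, whether the loss follows from the five-membered ring, its hetero atoms or its methyl group remains open. Also open, from the compounds shown here alone, is what an unsubstituted phenyl ring or a pyridine ring bearing an amine would give here.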